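The source may report more compounds than this note shows. Statements on the series, on what has been measured and on what is new or still open speak of the compounds shown alone.

Measured compounds:
Compound 1, `O[C@@H](c1ccccc1)[C@H]1CO[C@H](c2ccccc2)[C@@H](C/C=C/c2cccc(F)c2)C1` — 9170 nM
Compound 2, `O=[N+]([O-])c1cccc(/C=C/C[C@H]2C[C@@H]([C@@H](O)c3ccccc3)CO[C@@H]2c2ccccc2)c1` — 6350 nM
Compound 3, `O[C@@H](c1ccccc1)[C@H]1CO[C@H](c2ccccc2)[C@@H](C/C=C/c2ccccc2F)C1` — 9530 nM

All three were tested in a functional assay on HL-60 cells (Homo sapiens) for cytotoxicity, read by WST assay, with a stated time of 48 h; on this read-out lower numbers stand for stronger inhibition and higher numbers for weaker inhibition. Compound 2 arises from compound 1 by nitro in place of fluoro on an aromatic carbon; that step gave a 1.4-fold lower number from compound 1 to compound 2 (0.16 log units; within the scatter). Compound 3 differs from compound 1 in its core by 2-fluorophenyl in place of 3-fluorophenyl on a double-bonded chain carbon bound to a double-bonded chain carbon, with a 1.0-fold higher number from compound 1 to compound 3 (0.02 log units; within the scatter). Compound 4, `O=[N+]([O-])c1ccccc1/C=C/C[C@H]1C[C@@H]([C@@H](O)c2ccccc2)CO[C@@H]1c1ccccc1`, has not yet been measured in this assay. It arises from compound 3 by nitro in place of fluoro on an aromatic carbon; this is the same kind of change as from compound 1 to compound 2, but the place differs: there it was meta to a large group, here it is ortho to a large group. Because a 1.4-fold lower number from compound 1 to compound 2 (0.16 log units; within the scatter) stayed within the scatter, compound 4 is expected to show a comparably small step, a 1.4-fold lower number from compound 3 to compound 4 (0.13 log units; within the scatter). Compound 4 is estimated at 7000 nM, between 3500 nM and 14000 nM.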

Compound 4, half-maximal inhibitory concentration: 7250 nM
For compound 4 the middle estimate is 1.0-fold (0.02 log units) below the measured one, within the range that was stated.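

In this assay, nitro in place of fluoro gave a 1.3-fold lower number from compound 3 to compound 4 (0.12 log units; within the scatter), 2-nitrophenyl in place of 3-nitrophenyl gave a 1.1-fold higher number from compound 2 to compound 4 (0.06 log units; within the scatter), and 2-nitrophenyl in place of 3-fluorophenyl gave a 1.3-fold lower number from compound 1 to compound 4 (0.10 log units; within the scatter). The change from fluoro to nitro read alike at both places on the ring: the same change on two cores in this assay, a 1.4-fold lower number (0.16 log units; within the scatter) from compound 1 to compound 2 and a 1.3-fold lower number (0.12 log units; within the scatter) from compound 3 to compound 4, 1.1-fold (0.04 log units) apart, within the scatter of two such steps This shows that the change stayed small on both cores, but with each step within the scatter it does not show that nitro differs from fluoro at all, nor that the result would hold on other cores.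

The compounds shown leave open how an amine or a carboxylic acid in place of nitro would read in this assay. They also leave open what a longer chain would do.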